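Replacing the dimethoxyphenyl amide with a naphthalene

The compounds below may be only part of what the source reports. "The series", "measured", "known", "first", "only" and "open" are said of these compounds alone.

Measured compounds:
Compound 1, `COc1ccc(C(=O)N[C@H]2CCN(Cc3ccc(OCCCN(C)C)cc3)C2)cc1OC`: in an assay on HEK293 cells for binding affinity to Urotensin-2 receptor (Homo sapiens), read by radioligand binding (on this read-out lower numbers stand for stronger inhibition and higher numbers for weaker inhibition), compound 1 gives < 10000 nM, which is a limit of the assay and not a number.
Compound 2, `CN(C)CCCOc1ccc(CN2CC[C@H](NC(=O)c3cccs3)C2)cc1`: compound 2 gives < 10000 nM, likewise only a limit.
Compound 3, `CN(C)CCCOc1ccc(CN2CC[C@H](NC(=O)c3cc4ccccc4o3)C2)cc1`: compound 3 gives 2510 nM.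

Compound 1 therefore stands only at a limit in this assay, and the step that the two limits leave unreadable from compound 1 to compound 2 cannot be read. Nor can a step that the limit leaves unreadable from compound 1 to compound 3 or a step that the limit leaves unreadable from compound 2 to compound 3 be sized, since (the limit of < 10000 nM in this assay, at which 2 of the 3 values shown sit). All three measured compounds share a core that carries an amide, and they differ only in the aromatic group on the carbonyl carbon.

Compound 4, `CN(C)CCCOc1ccc(CN2CC[C@H](NC(=O)c3ccc4ccccc4c3)C2)cc1`, is not yet measured. It differs from compound 1 as follows: naphthalen-2-yl in place of 3,4-dimethoxyphenyl on a carbonyl carbon. For the measured compounds named here, the only numerical anchor is compound 3, whose bicyclic aromatic group gives 2510 nM; compound 4 also carries a bicyclic aromatic group on the carbonyl carbon. Going by the values given here, no measured step gives a direction from compound 1, so an expectation can only be anchored near compound 3. Compound 4 is therefore expected to give about 3000 nM, within 800 nM to 10000 nM, an estimated step that the limit leaves unreadable from compound 1 to compound 4.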

Compound 4, inhibition constant: < 10000 nM
Compound 4 was reported as a limit; the forecaster's own chance of this, stated with the estimate: 30%; the middle value is on the limit's open side.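

For the compounds shown here, compound 4 is reported only as a limit of the assay, so no step from compound 1, compound 2 or compound 3 to compound 4 can be read: the limit of < 10000 nM in this assay, at which 3 of the 4 values shown sit.

The compounds shown leave open how compound 1, compound 2 and compound 4 actually compare with compound 3 or with one another.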